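This account rests on a few compounds, and the source may have more. Where it says the series, first, only, none or still open, it means among the compounds named here.

Measured in a functional assay on SNB-19 cells (Homo sapiens) for inhibition, read by MTT assay, with a stated time of 7 days; a higher number here means a weaker inhibitor of growth, a lower number a stronger inhibitor of growth:

- Compound 1 `C[Si](C)(C)CCOCn1nnc2c(C(N)=O)ncn2c1=O`: 29900 nM
- Compound 2 `NC(=O)c1ncn2c(=O)n(Cc3ccccc3)nnc12`: > 50000 nM (a limit, not a number)
- Compound 3 `COc1cccc(Cn2nnc3c(C(N)=O)ncn3c2=O)c1`: > 50000 nM (a limit, not a number)

Compound 2 has no exact value on these numbers, only the limit > 50000 nM. Much of the evidence so far is of this kind: the limit of > 50000 nM in this assay, at which 2 of the 3 values shown sit.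

Compound 4 `COc1ccc(Cn2nnc3c(C(N)=O)ncn3c2=O)cc1` differs from compound 2 in one place: methoxy in place of hydrogen on an aromatic carbon. The new methoxy sits para to a large group.

The closest measured step is the same exchange, methoxy in place of hydrogen on an aromatic carbon: a step that the two limits leave unreadable from compound 2 to compound 3. It therefore gives no size to carry over. The other measured step, an at least 1.6-fold higher number from compound 1 to compound 2 (0.22 log units; that floor lies within the scatter), concerns a different exchange, a whole group on the saturated chain carbon, and it says nothing direct about methoxy.

With neither step pointing to a gain or a loss, no step beyond the usual scatter is expected in this assay. The expected step is a number no higher from compound 2 to compound 4 (the limit leaves the size open). A further report of only a limit is the likeliest outcome. For compound 4 the estimated value is 50000 nM, with an expected range from 28000 nM to 90000 nM.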

Compound 4, concentration for 50% growth inhibition: > 50000 nM
Compound 4: only a limit was reported (the forecaster's own chance of this, stated with the estimate: 75%); the middle value sits exactly at the limit.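

No step can be read from compound 2 to compound 4, because both compounds are reported only as a limit and not as a number: the limit of > 50000 nM in this assay, at which 3 of the 4 values shown sit. The compounds shown leave open whether methoxy in place of hydrogen on an aromatic carbon changes growth inhibition at all, since compound 2, compound 3 and compound 4 have no exact value.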